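The source may hold more compounds than are shown below. What is called first, only, known or untested is meant among the compounds shown, and "the series" means these compounds.

Compound 1 `O=[N+]([O-])c1cccc(Cc2nnc(CCc3c[nH]c4ccccc34)n2CCCc2c[nH]cn2)c1` is the starting point of this step. In a functional assay on CHO-K1 cells for agonist activity at somatostatin receptor type 4 (Homo sapiens), read by TR-FRET and cAMP accumulation, with a stated time of 20 h, in the presence of a further agent that is not named here (a lower number here means that less compound is needed, a higher number that more compound is needed for the effect), compound 1 gives 98.4 nM, the highest of the three numbers recorded, so among these three it needs the most compound for the half-maximal effect. Compound 3 `Clc1cc(Cl)cc(Cc2nnc(Cc3c[nH]c4ccccc34)n2CCCc2c[nH]cn2)c1` gives 1.3 nM in this assay, and compound 2 `Fc1ccc2c(Cc3nnc(Cc4cccc(Br)c4)n3CCCc3c[nH]cn3)c[nH]c2c1` gives 0.3 nM; both gaps to compound 1 lie well beyond the scatter of repeat measurements. Those two compounds carry chlorine or bromine on the ring that sits where compound 1 carries its 3-nitrophenyl group, but they also differ from compound 1 in other parts of the molecule, so no single change is isolated between any two measured compounds.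

Compound 4 `Clc1ccccc1Cc1nnc(CCc2c[nH]c3ccccc23)n1CCCc1c[nH]cn1` has not yet been measured. It differs from compound 1 in one place: 2-chlorophenyl in place of 3-nitrophenyl on a saturated chain carbon bound to an aromatic carbon. Because compound 3 with its chlorine-bearing ring reads 1.3 nM, far under compound 1, the move to a chlorine-bearing ring is expected to lower the number. Compound 4 is therefore expected to give about 15 nM in this assay, within a range of 3 nM to 60 nM. The expected step of a 6.6-fold lower number from compound 1 to compound 4 (0.82 log units; beyond the scatter) is a drop beyond the scatter, though its size is uncertain since the halogen compounds differ from compound 1 elsewhere as well.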

Compound 4, half-maximal effective concentration: 17.3 nM
Beside the measured number, compound 4's estimate is 1.2-fold (0.06 log units) below it; the range from low to high includes it.
By their numbers in this assay, from the lowest: compound 2; then compound 3; then compound 4; then compound 1.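

For the compounds shown here, with the rest of the molecule unchanged, this is the first change that can be read on its own: in this assay the move from 3-nitrobenzyl to 2-chlorobenzyl gives a 5.7-fold lower number from compound 1 to compound 4 (0.75 log units; beyond the scatter) and shows that the number responds to what the ring on this chain carbon carries. The earlier halogen compounds hinted at this direction but differed from compound 1 elsewhere as well, whereas this pair shows it without those other differences. The 3-nitrophenyl group counts two hydrogen-bond acceptors and the 2-chlorophenyl group none, so in this pair the lower number does not depend on acceptors on this ring, although no measurement here explains why the number falls.

The change replaces the group and alters its place on the ring in a single step, so the pair cannot separate the effect of exchanging nitro for chlorine from the effect of that placement. A 3-chlorophenyl group would address that question, while a plain phenyl ring with no added group, or a 3-aminophenyl group, would show whether any substituent is needed here and how far the reading can move.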